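Acetyl and Amino Variants on a Shared Core

This account rests on a few compounds, and the source may have more. Where it says the series, first, only, none or still open, it means among the compounds named here.

Measured compounds:
- compound 1 `COc1ccc(-c2c[nH]c(=O)n2-c2cc(OC)c(OC)c(OC)c2)cc1[N+](=O)[O-]`: > 50000 nM
- compound 2 `COc1ccc(-c2c[nH]c(=O)n2-c2cc(OC)c(OC)c(OC)c2)cc1N`: > 50000 nM
- compound 3 `COc1ccc(-c2cn(C(C)=O)c(=O)n2-c2cc(OC)c(OC)c(OC)c2)cc1[N+](=O)[O-]`: 30800 nM

In a functional assay on ECa-109 cells (Homo sapiens) for cytotoxicity, read by MTT assay, with a stated time of 48 h (a higher number here means a weaker inhibitor, a lower number a stronger inhibitor), compound 1 reaches only a limit of the assay, > 50000 nM. Compound 2 likewise reaches only a limit in this assay, > 50000 nM. Among the compounds with values here, compound 3 is the one compound with a number, giving 30800 nM in this assay.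

Compound 2 differs from compound 1 by amino in place of nitro on an aromatic carbon. The step that the two limits leave unreadable from compound 1 to compound 2, because both values sit at the limit of > 50000 nM in this assay, at which 2 of the 3 values shown sit.

Compound 3 differs from compound 1 by acetyl in place of hydrogen on an aromatic nitrogen. The step of an at least 1.6-fold lower number from compound 1 to compound 3 (0.21 log units; that floor lies within the scatter).

Compound 4 `COc1ccc(-c2cn(C(C)=O)c(=O)n2-c2cc(OC)c(OC)c(OC)c2)cc1N` has not yet been measured. It differs from compound 3 by amino in place of nitro on an aromatic carbon. This is the same change as from compound 1 to compound 2, and it occurs twice among these compounds; the surroundings of the place are the same in both cases. Since that earlier step was unreadable, it gives no size to carry over.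

Compound 4 is expected to give 40000 nM in this assay, with a range from 15000 nM to 100000 nM. The step of a 1.3-fold higher number from compound 3 to compound 4 (0.11 log units; within the scatter) is estimated to stay small, resting on compound 3 at 30800 nM and on the absence of any readable step from the earlier pair. A reported limit rather than a number is considered quite possible for compound 4.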

Compound 4, half-maximal inhibitory concentration: > 50000 nM
Compound 4 was reported as a limit; the forecaster's own chance of this, stated with the estimate: 45%; at least 1.2-fold (0.09 log units) between middle value and limit.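

In this assay, amino in place of nitro gives an at least 1.6-fold higher number from compound 3 to compound 4 (0.21 log units; that floor lies within the scatter) on the acetyl-bearing core. Compound 4 is reported only as a limit, and the step is a floor that lies within the scatter: it shows no firm change on this core and does not exclude a larger one. Whether the change carries from one core to the other at the same size stays unanswered, because the steps from compound 1 to compound 2 and from compound 2 to compound 4 cannot be read, each pair sitting at one limit: the limit of > 50000 nM in this assay, at which 3 of the 4 values shown sit.

The compounds shown leave open whether another group in place of nitro and amino, such as a hydroxyl, a carboxylic acid or a methylamino group, would give a readable number on either core. They also leave open whether a longer chain than acetyl on the aromatic nitrogen, such as butanoyl, would bring a value further from that limit. Among these compounds only compound 3 has a number, 30800 nM in this assay.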